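Changing the amide group: what to expect for compound 4

The compounds below may be only part of what the source reports. "The series", "measured", "known", "first", "only" and "open" are said of these compounds alone.

Three compounds have been measured in an assay on HEK293 cells for positive allosteric modulation of metabotropic glutamate receptor 5 (Homo sapiens), read by FLIPR, with a stated time of 1 h; on this read-out higher numbers stand for an effect only at larger amounts of compound and lower numbers for an effect already at smaller amounts:

Compound 1 `O=C1NCCc2nc(C#Cc3ccccc3F)sc21`: 1500 nM
Compound 2 `CN1CCc2nc(C#Cc3ccccc3)sc2C1`: 34 nM
Compound 3 `O=C(C1CC(F)C1)N1CCc2nc(C#Cc3ccccc3)sc2C1`: 85 nM

Compound 3 holds the second highest of these three numbers; compound 2 sits nearest to it, compound 1 furthest away. Compound 4 `N#Cc1cccc(C(=O)N2CCc3nc(C#Cc4ccccc4)sc3C2)c1` differs from compound 3 in one place: 3-cyanophenyl in place of 3-fluorocyclobutyl on a carbonyl carbon. For the measured compounds named here, the only measured step touching this part of the molecule is a 2.5-fold higher number from compound 2 to compound 3 (0.40 log units; beyond the scatter), where a (3-fluorocyclobutyl)carbonyl replaced a methyl on an amine nitrogen in a ring. Going by the values given here, no measured pair sets one amide group against another, so that step is only a loose guide. The expected change is therefore small, a 1.1-fold higher number from compound 3 to compound 4 (0.02 log units; within the scatter), not clearly beyond the scatter. Compound 4 is estimated at 90 nM, within a range from 30 nM to 270 nM.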

Compound 4, half-maximal effective concentration: 71 nM
For compound 4 the middle estimate is 1.3-fold (0.10 log units) above the measured one; the measured number falls inside the stated range.
By their numbers in this assay, from the lowest: compound 2; then compounds 4 and 3 (each within the scatter of the next); then compound 1.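

In this assay, 3-cyanophenyl in place of 3-fluorocyclobutyl on the carbonyl carbon gives a 1.2-fold lower number from compound 3 to compound 4 (0.08 log units; within the scatter). This position therefore accepts an aromatic ring carrying a nitrile, with more heavy atoms than the four-membered ring, and the number shows no change beyond the scatter. The data offer no measured explanation for this. Still open, from the compounds shown here alone, is whether the nitrile matters at all, which a plain phenyl would test. Also open, going by these compounds, is how an amine or a carboxylic acid on that ring would compare.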